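The compounds below may be only part of what the source reports. "The series", "measured", "known", "first", "only" and "open" are said of these compounds alone.

Three compounds of a shared core have numbers in a functional assay on CHO cells for inhibition of metabotropic glutamate receptor 5 (Rattus norvegicus), read by FLIPR and calcium flux; a lower number here means a stronger inhibitor, a higher number a weaker inhibitor. Compound 1 `COc1cccc(-c2ccc3ccc(C)nc3c2)c1` gives 860 nM in this assay. Compound 2 `Cc1ccc2ccc(-c3ccc(C#N)cc3)cc2n1` reaches only the limit of this assay, reported as > 10000 nM, so no number is known for it; this is the limit described as the limit of > 10000 nM in this assay, at which 1 of the 3 values shown sits. Compound 3 `Cc1ccc2ccc(-c3cc(C#N)cc(C#N)c3)cc2n1` gives 2 nM in this assay, the lowest of the two numbers shown, and its gap to compound 1 lies beyond the usual scatter of repeated measurements.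

Compound 4 `Cc1ccc2ccc(-c3cc(C#N)cc(OC(C)C)c3)cc2n1` has not yet been measured. It differs from compound 3 in one place: isopropoxy in place of cyano on an aromatic carbon. Since compound 1 carries an alkoxy group on that ring and gives 860 nM, while compound 3 with two cyano groups gives 2 nM, the exchange is expected to weaken inhibition, and the step from compound 3 to compound 4 is estimated at a 25-fold higher number from compound 3 to compound 4 (1.40 log units; beyond the scatter) in this assay. For compound 4 the expected value in this assay is 50 nM, likely within 8 nM to 400 nM.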

Compound 4, half-maximal inhibitory concentration: 310 nM
Beside the measured number, compound 4's estimate is 6.2-fold (0.79 log units) below it, within the range that was stated.
By their numbers in this assay, from the lowest: compound 3; then compound 4; then compound 1. At a limit, above all of these: compound 2.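

In this assay there is a 160-fold higher number from compound 3 to compound 4 (2.19 log units; beyond the scatter) when isopropoxy replaces one cyano group and the group meta to it, the other cyano, stays unchanged. This is the first pair shown that differs in one place, so it is the first direct reading of this position: the change at this single aromatic carbon alone moves the number by a large step, and the larger isopropoxy group, with 4 heavy atoms against 2, still leaves a measurable inhibitor. Nothing shown gives a cause for this step.

Going by these compounds, whether the loss comes from removing cyano or from adding isopropoxy stays open, since only one replacement at this carbon can be read. On these data alone, how a small methyl group, an amine or a carboxylic acid would read at this position also stays open.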